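A few compounds are considered here, and "the series" means these few. Any claim that something is new, unique, unknown or untested is made for them only; others in the source may bear on it.

Measured compounds in a functional assay on A549 cells (Homo sapiens) for antiproliferative activity, read by MTT assay, with a stated time of 72 h; on this read-out higher numbers stand for weaker inhibition and lower numbers for stronger inhibition:

- compound 1 `O=C(Nc1ccccc1)C(Cl)Cl`: 130000 nM
- compound 2 `Cc1ccc(NC(=O)C(Cl)Cl)cc1`: 48900 nM
- compound 3 `O=C(Nc1ccc(F)cc1)C(Cl)Cl`: 68400 nM

Compound 3 sits second highest of the three numbers in this assay. Its nearest neighbour is compound 2, and the gap from compound 2 to compound 3 is a 1.4-fold higher number from compound 2 to compound 3 (0.15 log units; within the scatter); its furthest is compound 1, and the gap from compound 1 to compound 3 is a 1.9-fold lower number from compound 1 to compound 3 (0.28 log units; within the scatter). Both gaps lie within the scatter, so compound 3 is not separated from either.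

Compound 4 `O=C(Nc1ccc(Cl)cc1)C(Cl)Cl` differs from compound 3 by chloro in place of fluoro on an aromatic carbon. Going by the values given here, no measured step involves a chloro substituent, so the nearest guides are the substitutions made at this same aromatic carbon: from compound 1 to compound 2 the step was a 2.7-fold lower number from compound 1 to compound 2 (0.42 log units; beyond the scatter), and from compound 1 to compound 3 it was a 1.9-fold lower number from compound 1 to compound 3 (0.28 log units; within the scatter), while from compound 2 to compound 3 it was a 1.4-fold higher number from compound 2 to compound 3 (0.15 log units; within the scatter). All substituent changes so far moved the number little, with only the methyl step beyond the scatter. A step of similar scale, if any, is therefore expected here, most likely a small lowering, and compound 4 is estimated at 45000 nM in this assay, with a range from 20000 nM to 110000 nM, corresponding to an expected step of a 1.5-fold lower number from compound 3 to compound 4 (0.18 log units; within the scatter).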

Compound 4, half-maximal inhibitory concentration: 20400 nM
Compound 4: the middle estimate sits 2.2-fold (0.34 log units) above what was measured, and the stated range covers the measured number.
By their numbers in this assay, from the lowest: compound 4; then compounds 2, 3 and 1 (each within the scatter of the next, the first and the last beyond it).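

At this aromatic carbon, the choice of halogen separates two compounds in this assay: chloro in place of fluoro gives a 3.4-fold lower number from compound 3 to compound 4 (0.53 log units; beyond the scatter), whereas the earlier fluoro and methyl compounds stayed within the scatter of each other. Chloro also separates from methyl, with a 2.4-fold lower number from compound 2 to compound 4 (0.38 log units; beyond the scatter), and from hydrogen, with a 6.4-fold lower number from compound 1 to compound 4 (0.80 log units; beyond the scatter). Compound 4 is therefore the only compound with steps to all three others beyond the scatter and is the strongest inhibitor shown, so the identity of the substituent matters here, not merely its presence.

Nothing shown accounts for the difference between chloro and fluoro. Going by these compounds, it remains open whether bromo, methoxy or an amine on the same carbon would lower the number further.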